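Acylguanidine series: isopropylsulfanyl in place of propyl

The compounds below may be only part of what the source reports. "The series", "measured", "known", "first", "only" and "open" are said of these compounds alone.

Measured so far:
compound 1 `CCCc1cc(C)c(C(=O)N=C(N)N)cc1S(C)(=O)=O`: 5.7 nM
compound 2 `Cc1cc(-c2cc(C(F)(F)F)cc(C(F)(F)F)c2)c(S(C)(=O)=O)cc1C(=O)N=C(N)N`: 2800 nM

In a functional assay for inhibition of sodium/hydrogen exchanger (Oryctolagus cuniculus) (a lower number here means a stronger inhibitor, a higher number a weaker inhibitor), compound 1 gives 5.7 nM, the lowest of the two numbers on record. Compound 2 gives 2800 nM, a gap far beyond the scatter, so compound 1 is the stronger inhibitor of the pair. Among the compounds with values here, no step between compounds that differ in one place is available, so nothing can be said about which part of compound 2 drives the difference.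

Compound 3 `Cc1cc(SC(C)C)c(S(C)(=O)=O)cc1C(=O)N=C(N)N` is not yet measured. It differs from compound 1 as follows: isopropylsulfanyl in place of propyl on an aromatic carbon. The group that enters is of similar size to the group that leaves, with a hydrogen-bond acceptor added where there was none.

Within the data shown here, with no analogous step on record, the expectation rests on the closeness in size of the two groups: the step of a 1.8-fold higher number from compound 1 to compound 3 (0.24 log units; within the scatter) is expected to be small, at most a modest weakening, and possibly not beyond the scatter. Compound 3 is therefore estimated at 10 nM, with a range from 3 nM to 40 nM.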

Compound 3, half-maximal inhibitory concentration: 12 nM
Beside the measured number, compound 3's estimate is 1.2-fold (0.08 log units) below it, and the stated range covers the measured number.
By their numbers in this assay, from the lowest: compound 1; then compound 3; then compound 2.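

In this assay, isopropylsulfanyl in place of propyl on an aromatic carbon, ortho to a methylsulfonyl group, gives a 2.1-fold higher number from compound 1 to compound 3 (0.32 log units; beyond the scatter), a modest step. Within the data shown here, this is the first single-place step on record for the series, and it gives this position its first direct reading: a branched group of 4 heavy atoms, carrying a sulfur and a hydrogen-bond acceptor, can replace the 3-carbon propyl chain at a limited cost, with compound 3 still at 12 nM. No supporting measurement bears on what lies behind this step.

The step changes the sulfur link and the branching together, and the compounds shown do not separate the two; an isopropyl group or a straight propylsulfanyl chain on the same carbon would each carry only one of these changes. Among these compounds, also open is how the number at this position responds to a group of a different kind, such as an amine or a carboxylic acid, since the one single-place step here covers only two groups.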